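This account rests on a few compounds, and the source may have more. Where it says the series, first, only, none or still open, it means among the compounds named here.

Measured compounds, with the half-maximal inhibitory concentration in a functional assay on MGC-803 cells (Homo sapiens) for antiproliferative activity, read by MTT assay, with a stated time of 48 h; a lower number here means a stronger inhibitor, a higher number a weaker inhibitor:
compound 1, `COc1ccc(CN(C(=O)CSc2nc3ccccc3s2)c2cc(OC)c(OC)c(OC)c2)cc1F`, gives 416 nM
compound 2, `COc1ccc(CN(C(=O)CSc2nc3ccccc3s2)c2cc(OC)c(OC)c(OC)c2)cc1C`, gives 6360 nM
compound 3, `COc1cc(CN(C(=O)CSc2nc3ccccc3s2)c2cc(OC)c(OC)c(OC)c2)cc(OC)c1OC`, gives 45700 nM

Compound 1 has the lowest number of the three and its steps to the other two lie beyond the scatter, so it is the strongest inhibitor here in this assay.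

Compound 4, `COc1ccc(CN(C(=O)CSc2nc3ccccc3s2)c2cc(OC)c(OC)c(OC)c2)cc1OC`, is not yet measured. It differs from compound 1 by methoxy in place of fluoro on an aromatic carbon.

For the measured compounds named here, two measured steps bear on this change. Swapping the same fluoro for a methyl gave a 15-fold higher number from compound 1 to compound 2 (1.18 log units; beyond the scatter). Replacing the whole 3-fluoro-4-methoxyphenyl with 3,4,5-trimethoxyphenyl gave a 110-fold higher number from compound 1 to compound 3 (2.04 log units; beyond the scatter), and from the methyl compound the same ring swap gave a 7.2-fold higher number from compound 2 to compound 3 (0.86 log units; beyond the scatter). Every departure from the fluoro so far has weakened inhibition, and adding a methoxy moves toward the trimethoxy pattern of compound 3, so a sizeable rise in the number is expected, though probably short of the full trimethoxy loss.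

For compound 4 in this assay the expected step is a 14-fold higher number from compound 1 to compound 4 (1.16 log units; beyond the scatter). The estimate for compound 4 is 6000 nM, in the range 1500 nM to 25000 nM.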

Compound 4, half-maximal inhibitory concentration: 34100 nM
Compound 4: middle estimate off by 5.7-fold (0.75 log units), on the low side; the whole stated range lies below it.
By their numbers in this assay, from the lowest: compound 1; then compound 2; then compounds 4 and 3 (each within the scatter of the next).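

In this assay, methoxy in place of fluoro at this position gives an 82-fold higher number from compound 1 to compound 4 (1.91 log units; beyond the scatter) and so removes almost all of the advantage of compound 1, a larger step than the one to methyl. The step of a 5.4-fold higher number from compound 2 to compound 4 (0.73 log units; beyond the scatter) also separates methoxy from methyl, giving the order fluoro, methyl, methoxy across compounds 1, 2 and 4. Hydrogen in place of methoxy gives a 1.3-fold lower number from compound 3 to compound 4 (0.13 log units; within the scatter) and lies within the scatter, so the third methoxy of compound 3 makes no readable difference once the 3,4-dimethoxyphenyl pattern is present.

Going by these compounds, whether chloro, hydroxyl or plain hydrogen in place of the fluoro would keep the number of compound 1 remains open. No evidence on the reason for this order is at hand.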